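This account rests on a few compounds, and the source may have more. Where it says the series, first, only, none or still open, it means among the compounds named here.

Measured compounds:
compound 1 `Cc1ccc(Cn2cc(COc3ccc4c(=O)ccoc4c3)nn2)cc1` — in an ADME assay on L02 cells (Homo sapiens) for cytotoxicity, read by MTT assay, with a stated time of 48 h (on this read-out higher numbers stand for weaker inhibition and lower numbers for stronger inhibition), compound 1 gives > 300000 nM.
compound 2 `O=c1ccoc2cc(OCc3cn(Cc4cccc(Br)c4)nn3)ccc12` — in this assay compound 2 gives > 300000 nM.

Both of these values are limits of the assay, not numbers. Compound 2 therefore stands only at a limit, as does compound 1, and the step that the two limits leave unreadable from compound 1 to compound 2 cannot be read in size. Compound 3 `Cc1ccccc1Cn1cc(COc2ccc3c(=O)ccoc3c2)nn1` is not yet measured. Its difference from compound 2 is 2-methylphenyl in place of 3-bromophenyl on a saturated chain carbon bound to an aromatic nitrogen. Going by the values given here, the one measured step bears on this change but is unreadable, with both values sitting at the limit of > 300000 nM in this assay, at which 2 of the 2 values shown sit. No step beyond the scatter is expected from compound 2 to compound 3, so a step that the limit leaves unreadable from compound 2 to compound 3 is estimated near zero. Compound 3 is expected at 400000 nM, estimated between 150000 nM and 1500000 nM.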

Compound 3, half-maximal inhibitory concentration: > 300000 nM
Compound 3 ended at the assay's limit; the forecaster's own chance of this, stated with the estimate: 85%; the middle value is on the limit's open side.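

Compound 3 gives a limit and not a number, so no step among compound 1, compound 2 and compound 3 can be read: the limit of > 300000 nM in this assay, at which 3 of the 3 values shown sit.

The compounds shown leave open whether these phenyl changes alter the read-out in this assay at all.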